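This account rests on a few compounds, and the source may have more. Where it says the series, first, only, none or still open, it means among the compounds named here.

Compound 1 `CN(C)CCCCCn1c2c(c3ccccc31)C(=O)c1c[n+]([O-])c3ccccc3c1C2=O`: 370 nM
Compound 2 `O=C1c2c[n+]([O-])c3ccccc3c2C(=O)c2c1c1ccccc1n2Cc1cn(CC(O)CO)nn1`: > 1000 nM

In a functional assay on SH-SY5Y cells (Homo sapiens) for cytotoxicity, read by MTT assay, with a stated time of 72 h (a higher number here means a weaker inhibitor, a lower number a stronger inhibitor), compound 1 gives 370 nM. Compound 2 reads > 1000 nM, which is a limit of the assay and not a number; it stands at the limit of > 1000 nM in this assay, at which 1 of the 2 values shown sits.

Compound 3 `CN1CCN(CCCCn2c3c(c4ccccc42)C(=O)c2c[n+]([O-])c4ccccc4c2C3=O)CC1` has not yet been measured. It keeps the shared core and differs from compound 2 by 3-(4-methylpiperazin-1-yl)propyl in place of 1-(2,3-dihydroxypropyl)-1H-1,2,3-triazol-4-yl on a saturated chain carbon bound to an aromatic nitrogen: 3-(4-methylpiperazin-1-yl)propyl in place of 1-(2,3-dihydroxypropyl)-1H-1,2,3-triazol-4-yl. Among the measured compounds shown here, only one measured step bears on this change, an at least 2.7-fold higher number from compound 1 to compound 2 (0.43 log units; beyond the scatter). That step installed the same 1-(2,3-dihydroxypropyl)-1H-1,2,3-triazol-4-yl in place of 4-(dimethylamino)butyl, and its size is known only as a bound. Compound 3 removes that group again and puts a different chain with a terminal amine group in its place, so a move back towards lower numbers in this assay is expected, of at least similar size if the new chain behaves like that of compound 1. The expected change is an at least 2.8-fold lower number from compound 2 to compound 3 (0.45 log units; beyond the scatter). For compound 3 the estimated value is 350 nM, with an expected range from 120 nM to 1000 nM.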

Compound 3, half-maximal inhibitory concentration: 100 nM
Compound 3: the middle estimate sits 3.5-fold (0.54 log units) above what was measured; the measured number lies below the stated range.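

In this assay, putting 3-(4-methylpiperazin-1-yl)propyl in place of 1-(2,3-dihydroxypropyl)-1H-1,2,3-triazol-4-yl on a saturated chain carbon bound to an aromatic nitrogen gives an at least 10-fold lower number from compound 2 to compound 3 (1.00 log units; beyond the scatter), so a chain ending in an amine again goes with a lower number at this position. The size of that step is only a bound, since one end of it is a limit of the assay and not a number: the limit of > 1000 nM in this assay, at which 1 of the 3 values shown sits. The two amine-ended chains are also not interchangeable. Putting 4-methylpiperazin-1-yl in place of (dimethylamino)methyl on a saturated chain carbon, four bonds along the chain from an aromatic nitrogen, gives a 3.7-fold lower number from compound 1 to compound 3 (0.57 log units; beyond the scatter), so the end group matters here and not only the presence of an amine.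

The compounds shown leave open whether a morpholine or piperidine ring on the same chain would give a similar number, and whether a shorter or longer chain would keep it. They also do not separate the triazole from its diol, which a triazole carrying a dimethylamino group could do.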